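Methyl to butoxy on a shared core

The source may hold more compounds than are shown below. What is called first, only, known or untested is meant among the compounds shown, and "the series" means these compounds.

Compound 1 `CCCCCCCCCCCCOc1ccc(C(=O)/C=C/c2c(/C=C/c3ccc(OC)cc3)cc(OC)cc2OC)cc1`: 7.9 ug/mL
Compound 2 `CCCC(C)Oc1ccc(C(=O)/C=C/c2c(/C=C/c3ccc(OC)cc3)cc(OC)cc2OC)cc1`: 9.4 ug/mL
Compound 3 `COc1ccc(/C=C/c2cc(OC)cc(OC)c2/C=C/C(=O)c2ccc(C)cc2)cc1`: 3.6 ug/mL

In a functional assay on A549 cells (Homo sapiens) for antiproliferative activity, read by MTT assay, with a stated time of 48 h (on this read-out higher numbers stand for weaker inhibition and lower numbers for stronger inhibition), compound 3 gives 3.6 ug/mL, the lowest number of the three and so the strongest inhibition among them. Compound 4 `CCCCOc1ccc(C(=O)/C=C/c2c(/C=C/c3ccc(OC)cc3)cc(OC)cc2OC)cc1` has not yet been measured. It differs from compound 3 in one place: butoxy in place of methyl on an aromatic carbon.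

For the measured compounds named here, two measured steps bear on this change. The closer one runs the same kind of exchange in reverse, with methyl replacing 1-methylbutoxy: a 2.6-fold lower number from compound 2 to compound 3 (0.42 log units; beyond the scatter). The other compares two chains on the same oxygen: a 1.2-fold higher number from compound 1 to compound 2 (0.08 log units; within the scatter). Chain length and shape therefore made little visible difference between compound 1 and compound 2, although no butoxy compound has been measured. Compound 4 is therefore expected to sit near these two chain-bearing compounds rather than near compound 3. The expected change is a 2.4-fold higher number from compound 3 to compound 4 (0.37 log units; beyond the scatter). For compound 4, the estimated value is 8.5 ug/mL, with an expected range of 5 ug/mL to 14 ug/mL.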

Compound 4, half-maximal inhibitory concentration: 8.7 ug/mL
Compound 4: the middle estimate sits 1.0-fold (0.01 log units) below what was measured; the measured number falls inside the stated range.
By their numbers in this assay, from the lowest: compound 3; then compounds 1, 4 and 2 (each within the scatter of the next).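

In this assay, butoxy in place of methyl, the change from 4-methylphenyl to 4-butoxyphenyl, gives a 2.4-fold higher number from compound 3 to compound 4 (0.38 log units; beyond the scatter) and so shows this exchange directly with an unbranched chain, not only with 1-methylbutoxy. The butoxy compound stays within the scatter of both longer or branched relatives, with removal of the branching methyl giving a 1.1-fold lower number from compound 2 to compound 4 (0.03 log units; within the scatter) and loss of octyl from the dodecyl chain giving a 1.1-fold higher number from compound 1 to compound 4 (0.04 log units; within the scatter) within this set. Chain length and branching therefore make no readable difference among compounds 1, 2 and 4, while compound 3 stands apart, and no measured evidence accounts for that gap.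

The compounds shown leave open whether the oxygen or the carbon chain separates compound 3 from the others. A methoxy group, a hydroxyl group or a plain butyl group at this place would bear on that question.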